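A few compounds are considered here, and "the series" means these few. Any claim that something is new, unique, unknown or untested is made for them only; others in the source may bear on it.

Compound 1, `C[C@@H](NC(=O)c1cccc(Cl)c1)[C@H]1CC[C@@H](c2ccnc3ccc(F)cc32)CC1`: 97 nM in an assay on blood for inhibition of Indoleamine 2,3-dioxygenase 1 (Homo sapiens), read by mass spectrometry, with stated times of 4 h and 18 h; a higher number here means a weaker inhibitor, a lower number a stronger inhibitor.
Compound 2, `C[C@@H](NC(=O)c1ccccc1Cl)[C@H]1CC[C@@H](c2ccnc3ccc(F)cc32)CC1`: 135 nM in this assay.

Within the data shown here, compound 2 gives the higher of these two numbers, but its only neighbour is compound 1, and the step of a 1.4-fold higher number from compound 1 to compound 2 (0.14 log units; within the scatter) lies within the usual scatter, so the two compounds cannot be told apart on these data. Compound 3, `C[C@@H](NC(=O)C12CCC(Cl)(CC1)CC2)[C@H]1CC[C@@H](c2ccnc3ccc(F)cc32)CC1`, has not yet been measured. It differs from compound 2 in one place: a group of 9 heavy atoms (8 carbon, 1 chlorine; 2 six-membered non-aromatic rings of carbon only) in place of a group of 7 heavy atoms (6 carbon, 1 chlorine; one six-membered aromatic ring of carbon only), on a carbonyl carbon. Among the measured compounds shown here, only one measured step exists, a 1.4-fold higher number from compound 1 to compound 2 (0.14 log units; within the scatter), and it merely exchanges a 3-chlorophenyl for a 2-chlorophenyl on the same carbonyl carbon; it keeps the aromatic ring, so it bears only loosely on a change that removes the aromatic ring altogether. It was within the scatter. For the measured compounds named here, with no closer precedent, no step beyond the scatter is expected in this assay, but the range must be wide. Compound 3 is expected near 200 nM, between 60 nM and 700 nM. The step this estimate implies, a 1.5-fold higher number from compound 2 to compound 3 (0.17 log units; within the scatter), is expected rather than measured.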

Compound 3, half-maximal inhibitory concentration: 579 nM
Estimate against measurement, compound 3: 2.9-fold (0.46 log units) below; the measured number falls inside the stated range.
By their numbers in this assay, from the lowest: compounds 1 and 2 (each within the scatter of the next); then compound 3.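

Moving the chlorine on the aromatic ring had left the number within the scatter, but replacing that ring does not: in this assay the change gives a 4.3-fold higher number from compound 2 to compound 3 (0.63 log units; beyond the scatter) and, measured against the other chlorophenyl compound, a 6.0-fold higher number from compound 1 to compound 3 (0.78 log units; beyond the scatter). The group on this carbonyl carbon therefore matters more than the earlier pair could show, although the change weakens inhibition without abolishing it, as compound 3 still gives 579 nM in this measurement. Nothing available explains why the number rises with this exchange.

Compound 3 differs from both neighbours in two ways at once, losing the aromatic ring and gaining a larger group of two non-aromatic rings, so the compounds shown cannot separate these two changes; a chlorocyclohexyl group, with a single non-aromatic ring, would bear directly on that question. Every compound shown also carries one chlorine on this group, which leaves its contribution open, and a plain phenyl ring would be the natural comparison.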